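A Chalcone Series: Swapping the Aryl Group on the Piperazine

The compounds below may be only part of what the source reports. "The series", "measured", "known", "first", "only" and "open" are said of these compounds alone.

This account concerns a small set of chalcone-type compounds that share a common core and differ in the groups attached to a six-membered non-aromatic ring with two nitrogens, all tested in a functional assay on HeLa cells (Homo sapiens) for inhibition, read by MTT assay; a lower number here means a stronger inhibitor, a higher number a weaker inhibitor. Compound 1 `COc1ccccc1N1CCN(CC(=O)Nc2ccc(C(=O)/C=C/c3cn(Cc4ccc(Br)cc4)nn3)cc2)CC1` gives 26400 nM in this assay. Compound 2 `CCCCCCCCCCn1cc(/C=C/C(=O)c2ccc(NC(=O)CN3CCN(C(=O)OC(C)(C)C)CC3)cc2)nn1` gives 30200 nM. Compound 3 `CCCCCCCCCCn1cc(/C=C/C(=O)c2ccc(NC(=O)CN3CCN(c4ccc([N+](=O)[O-])cc4)CC3)cc2)nn1` gives 65900 nM, the highest number of the three, with the step of a 2.2-fold higher number from compound 2 to compound 3 (0.34 log units; beyond the scatter) lying beyond the scatter and compound 1 showing a lower number still.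

The next compound, compound 4 `CCCCCCCCCCn1cc(/C=C/C(=O)c2ccc(NC(=O)CN3CCN(c4ccccc4OC)CC3)cc2)nn1`, differs from compound 3 by the change (2-methoxyphenyl in place of 4-nitrophenyl on an amine nitrogen in a ring). Among the measured compounds shown here, the only measured step at the same place, a 2.2-fold higher number from compound 2 to compound 3 (0.34 log units; beyond the scatter), shows that the aryl group on that ring nitrogen can shift the number by a modest amount. Compound 1 carries the same 2-methoxyphenyl group, and its value of 26400 nM sits below that of compound 3. On that basis the step of a 2.1-fold lower number from compound 3 to compound 4 (0.31 log units; beyond the scatter) is expected to bring the number down modestly. Compound 4 is therefore estimated at 32000 nM, within a range from 15000 nM to 70000 nM.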

Compound 4, half-maximal inhibitory concentration: 50800 nM
Compound 4: the middle estimate sits 1.6-fold (0.20 log units) below what was measured; measured number inside the range.
By their numbers in this assay, from the lowest: compounds 1, 2, 4 and 3 (each within the scatter of the next, the first and the last beyond it).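

In this assay, the change gives a 1.3-fold lower number from compound 3 to compound 4 (0.11 log units; within the scatter), so 2-methoxyphenyl and 4-nitrophenyl on this ring nitrogen cannot be told apart, even though they differ in their atoms and hydrogen-bond acceptors. The step beyond the scatter seen with 4-nitrophenyl is not repeated with 2-methoxyphenyl, which gives a 1.7-fold higher number from compound 2 to compound 4 (0.23 log units; within the scatter), and the change away from the ring nitrogen, with 2-methoxyphenyl held fixed, gives a 1.9-fold higher number from compound 1 to compound 4 (0.28 log units; within the scatter) and likewise stays within the scatter. No evidence offered here accounts for these numbers. The compounds shown leave open whether a free amine hydrogen, a plain phenyl or a 4-methoxyphenyl on the ring nitrogen would move the number beyond the scatter. They also leave open whether a carboxylic acid on that aryl ring would do so.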